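Swapping a Terpene Chain for Trifluoromethyl in Cyclopropane Hydrazides

The compounds below may be only part of what the source reports. "The series", "measured", "known", "first", "only" and "open" are said of these compounds alone.

Compound 1 `O=C(NNc1nncc2ccccc12)C1CC1c1ccc(OCC(F)(F)F)cc1` gives 48000 nM in a functional assay on A549 cells (Homo sapiens) for inhibition, read by MTT assay, with a stated time of 72 h; on this read-out lower numbers stand for stronger inhibition and higher numbers for weaker inhibition.
Compound 2 `CC(C)=CCC/C(C)=C/COc1ccc(C2CC2C(=O)NNc2nncc3ccccc23)cc1` gives 36000 nM in this assay.
Compound 3 `CC(C)=CCC/C(C)=C/COc1ccc(C2CC2C(=O)NNC(=O)c2ccncc2)cc1` gives 78000 nM in this assay.

Compound 2 and compound 3 carry the same chain on the aromatic ring but differ in their cores: a group of 8 heavy atoms (6 carbon, 1 nitrogen, 1 oxygen; one six-membered aromatic ring with 1 hetero atom) in place of a group of 10 heavy atoms (8 carbon, 2 nitrogen; one six-membered aromatic ring of carbon only, one six-membered aromatic ring with 2 hetero atoms), on an amine nitrogen. That difference gave a 2.2-fold higher number from compound 2 to compound 3 (0.34 log units; beyond the scatter). Compound 1 keeps the core of compound 2 and changes only the chain: trifluoromethyl in place of 2,6-dimethylhepta-1,5-dien-1-yl on a saturated chain carbon bound to an oxygen on an aromatic ring, which gave a 1.3-fold higher number from compound 2 to compound 1 (0.12 log units; within the scatter). Compound 4 `O=C(NNC(=O)C1CC1c1ccc(OCC(F)(F)F)cc1)c1ccncc1` has not been measured; it arises from compound 3 by the same change at the same place, (trifluoromethyl in place of 2,6-dimethylhepta-1,5-dien-1-yl on a saturated chain carbon bound to an oxygen on an aromatic ring). Compound 4 is expected to show a step of a 1.2-fold higher number from compound 3 to compound 4 (0.09 log units; within the scatter), because the same change made a 1.3-fold higher number from compound 2 to compound 1 (0.12 log units; within the scatter), a step within the scatter. Compound 4 is therefore estimated at 95000 nM in this assay, with a likely range from 40000 nM to 250000 nM.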

Compound 4, half-maximal inhibitory concentration: 10000 nM
Compound 4: middle estimate off by 9.5-fold (0.98 log units), on the high side; measured number below the stated range.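

Trifluoromethyl in place of 2,6-dimethylhepta-1,5-dien-1-yl gave a 7.8-fold lower number from compound 3 to compound 4 (0.89 log units; beyond the scatter), a clear gain on the core of compound 3. The change did not carry over with the same size from one core to the other in this assay: the same change on two cores in this assay, a 1.3-fold higher number (0.12 log units; within the scatter) from compound 2 to compound 1 and a 7.8-fold lower number (0.89 log units; beyond the scatter) from compound 3 to compound 4, 10-fold (1.02 log units) apart, beyond the scatter of two such steps. This shows that the result of this change depended on the core in these two pairs, but it does not show why, and two pairs set no rule for other cores in the series.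

Going by these compounds, it remains open whether a plain ethyl group or a longer fluorinated chain in the same place would also give different results on the two cores. An amine or a carboxylic acid at the end of that chain is equally untested by the compounds shown here.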